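Swapping a bromine for a sulfonamide on the cytotoxicity read-out

The source may report more compounds than this note shows. Statements on the series, on what has been measured and on what is new or still open speak of the compounds shown alone.

Two compounds share one core and differ only in a single group on a benzene-type ring. Compound 1 `O=C(Nc1nc(-c2cccc(F)c2)cs1)c1ccc([N+](=O)[O-])o1` carries fluoro there; in an ADME assay on Vero cells (Chlorocebus sabaeus) for cytotoxicity, read by MTT assay, with a stated time of 72 h (on this read-out lower numbers stand for stronger inhibition and higher numbers for weaker inhibition), compound 1 gives 51600 nM. Compound 2 `O=C(Nc1nc(-c2cccc(Br)c2)cs1)c1ccc([N+](=O)[O-])o1` carries bromo in the same place, and in this assay compound 2 gives 71000 nM. Among the compounds with values here, the only measured step, a 1.4-fold higher number from compound 1 to compound 2 (0.14 log units; within the scatter), shows that exchanging these two halogens left the read-out essentially unchanged. Among the two measured values, compound 2 holds the higher number, but since the gap to compound 1 is within the scatter the two compounds cannot be told apart.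

Compound 3 `CS(=O)(=O)Nc1cccc(-c2csc(NC(=O)c3ccc([N+](=O)[O-])o3)n2)c1` is the next member. It differs from compound 2 by methanesulfonamido in place of bromo on an aromatic carbon. Within the data shown here, no measured step involves a group of this kind, so the one available step, which concerns two halogens only, offers no direct guide. In the absence of evidence for a shift, the number for compound 3 is expected to sit close to that of compound 2, and the expected step of a 1.1-fold higher number from compound 2 to compound 3 (0.02 log units; within the scatter) is therefore small. The estimate for compound 3 in this assay is 75000 nM, with a range from 30000 nM to 190000 nM.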

Compound 3, half-maximal inhibitory concentration: < 2820 nM
Compound 3: only a limit was reported; the forecaster's own chance of this, stated with the estimate: 20%; at least 26-fold (1.42 log units) between middle value and limit.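

At this place on the ring, the two halogens could not be told apart, but the methanesulfonamido group gives a very different result in this assay: an at least 25-fold lower number from compound 2 to compound 3 (1.40 log units; beyond the scatter), and against the fluoro compound, an at least 18-fold lower number from compound 1 to compound 3 (1.26 log units; beyond the scatter). The earlier pair showed only that one halogen can replace the other without a readable change, whereas this step shows that the read-out does respond to what sits at this position, moving strongly towards greater inhibition. The figure for compound 3 is a limit and not an exact number: the limit of < 2820 nM in this assay, at which 1 of the 3 values shown sits.

The change replaces a single halogen atom with a group containing carbon, nitrogen, oxygen and sulfur, so these compounds cannot show which part of the methanesulfonamido group matters, or how far compound 3 lies past its limit. An amine, a carboxylic acid or a methoxy group at the same place could help show whether the shift needs the sulfonyl unit or the hydrogen on its nitrogen, or whether other groups with no halogen behave in the same way.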